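A few compounds are considered here, and "the series" means these few. Any claim that something is new, unique, unknown or untested is made for them only; others in the source may bear on it.

Compound 1 `CCCCCCCCCCCC(=O)N[C@H](CCC(=O)NC(CCCC(N)C(=O)O)C(=O)O)C(=O)O` gives 0.027 nM in a functional assay on HEK293 cells for agonist activity at Nucleotide-binding oligomerization domain-containing protein 1 (Homo sapiens), read by spectrophotometry; on this read-out higher numbers stand for an effect only at larger amounts of compound and lower numbers for an effect already at smaller amounts.
Compound 2 `CCCCCCCCCCCC(=O)N[C@H](CCC(=O)NC(CCCC1NC(N)=NC1=O)C(=O)O)C(=O)O` gives 1.31 nM in this assay.
Compound 3 `CCCCCCCCCCCOC(=O)[C@@H](CCC(=O)NC(CCCC(N)C(=O)O)C(=O)O)NC(=O)CCCCCCCCCCC` gives 0.134 nM in this assay.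

Compound 3 stands second highest of these three numbers: compound 1 sits nearest, and compound 2 sits furthest, with the higher number. Compound 4 `CCCCCCCCCCCC(=O)N[C@H](CCC(=O)NC(CCCC(N)C(=O)O)C(=O)O)C(=O)OCC` differs from compound 3 by hydrogen in place of nonyl on a saturated chain carbon, two bonds along the chain from an oxygen next to a carbonyl group. For the measured compounds named here, the only measured step that touches this part of the structure is a 5.0-fold higher number from compound 1 to compound 3 (0.70 log units; beyond the scatter), where hydrogen on that oxygen became undecyl. Compound 4 keeps a short ethyl there, between the two ends of that step, so a modest move back toward compound 1 is expected, a 2.2-fold lower number from compound 3 to compound 4 (0.35 log units; beyond the scatter). Compound 4 is therefore estimated at 0.06 nM, with a likely range from 0.02 nM to 0.2 nM.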

Compound 4, half-maximal effective concentration: 0.069 nM
The estimate for compound 4 lay 1.2-fold (0.06 log units) below the measured number; measured number inside the range.
By their numbers in this assay, from the lowest: compound 1; then compounds 4 and 3 (each within the scatter of the next); then compound 2.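

Shortening the undecyl ester to the ethyl ester gives a 1.9-fold lower number from compound 3 to compound 4 (0.29 log units; within the scatter), so across these two compounds the length of the chain on this oxygen makes no readable difference. Even the small ethyl group on an oxygen next to a carbonyl group is enough for a modest change, with a 2.6-fold higher number from compound 1 to compound 4 (0.41 log units; beyond the scatter). No measurement shown offers an explanation for this shift. Still open, as far as these compounds go, is how a methyl or a benzyl group on that oxygen would behave. Also open, from the compounds shown here alone, is whether an amide in place of the ester would give a similar number.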